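This account rests on a few compounds, and the source may have more. Where it says the series, first, only, none or still open, it means among the compounds named here.

Measured so far in an ADME assay on a cell-free system (plasma, Homo sapiens) for protein binding, read by LC-MS, with a stated time of 4 h, tested at 5 uM; on this read-out higher numbers stand for a larger free fraction and lower numbers for a smaller free fraction:
compound 1 `O=C(NCc1ccc(S(=O)(=O)c2cccc(C(F)(F)F)c2)cc1)c1cc2cnccc2[nH]1`: 0.006
compound 2 `O=C(NCc1ccc(S(=O)(=O)c2cccc(C(F)(F)F)c2)cc1)c1cc2ccncc2o1`: 0.01

Compound 2 stands at 0.01, within the scatter of compound 1, so the two cannot be ranked. The next analogue is compound 3 `O=C(NCc1ccc(S(=O)(=O)c2cccc(C(F)(F)F)c2)cc1)c1cc2ccncc2s1`, with this change: a group of 9 heavy atoms (7 carbon, 1 nitrogen, 1 sulfur; one five-membered aromatic ring with 1 hetero atom, one six-membered aromatic ring with 1 hetero atom) in place of a group of 9 heavy atoms (7 carbon, 1 nitrogen, 1 oxygen; one five-membered aromatic ring with 1 hetero atom, one six-membered aromatic ring with 1 hetero atom), on a carbonyl carbon. For the measured compounds named here, the only measured step that bears on it is a 1.7-fold higher number from compound 1 to compound 2 (0.22 log units; within the scatter), an exchange on the same carbonyl carbon that stayed within the scatter. This is a single step, and no sulfur-containing group has been measured yet, so the evidence is thin. No change beyond the scatter is therefore expected in this assay. The estimated 1.3-fold lower number from compound 2 to compound 3 (0.10 log units; within the scatter) is expected to stay within the scatter. For compound 3 the expected unbound fraction is 0.008, with an estimated range of 0.004 to 0.016.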

Compound 3, unbound fraction: 0.004
Compound 3: the middle estimate sits 2.0-fold (0.30 log units) above what was measured; the range from low to high includes it.
By their numbers in this assay, from the lowest: compounds 3, 1 and 2 (each within the scatter of the next, the first and the last beyond it).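

Working from this assay, the exchange of oxygen for sulfur in the group on the carbonyl carbon gives the first step at this position that lies beyond the scatter (a 2.5-fold lower number from compound 2 to compound 3 (0.40 log units; beyond the scatter)), though the step is modest. The same sulfur-containing group stays within the scatter of the group in compound 1 (a 1.5-fold lower number from compound 1 to compound 3 (0.18 log units; within the scatter)), so only compound 2 and compound 3 can be ranked against each other, and compound 1 cannot be ranked against either. No measured property of these groups is available to account for the step.

Still open, on these data alone, is whether an amine or a carboxylic acid attached to this aromatic group would shift the unbound fraction further. Also open, as far as these compounds go, is how replacing the trifluoromethyl group, common to all three compounds, with a nitrile would affect it.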